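The source may hold more compounds than are shown below. What is called first, only, known or untested is meant among the compounds shown, and "the series" means these compounds.

Measured compounds:
Compound 1, `CC1=C(C(=O)OC(C)(C)C)C(c2ccco2)NC(=O)N1C`, gives 54% in an assay on membranes from HeLa cells for displacement of a labelled ligand from adenosine receptor A3 (Homo sapiens), read by scintillation counting, with a stated time of 180 min, tested at 1 uM; a higher number here means more inhibition at the concentration tested (going by the name of the read-out), a lower number less inhibition.
Compound 2, `CC1=C(C(=O)OCc2ccccc2)C(c2ccco2)NC(=O)N1C`, gives 11% in this assay.
Compound 3, `CC1=C(C(=O)OC(C)(C)C)C(c2cccs2)NC(=O)N1C`, gives 22% in this assay.

Compound 1 and compound 2 differ by benzyl in place of tert-butyl on an oxygen next to a carbonyl group, and this change gives a number 43 percentage points lower from compound 1 to compound 2 (beyond the scatter). Compound 1 and compound 3 differ by thiophen-2-yl in place of furan-2-yl on a saturated ring carbon, with a number 32 percentage points lower from compound 1 to compound 3 (beyond the scatter). Compound 4, `CC1=C(C(=O)OCc2ccccc2)C(c2cccs2)NC(=O)N1C`, has not been measured in this assay. It differs from compound 3 by benzyl in place of tert-butyl on an oxygen next to a carbonyl group, which is the same change as that from compound 1 to compound 2, made on the core of compound 3 in place of the core of compound 1; the two cores differ as described above. Among the compounds with values here, the one earlier instance of this change lowered the number by a large amount, and compound 3 starts from a lower number than compound 1. A step as large as the earlier one cannot be taken in full, since the read-out cannot fall far below zero, so a smaller step is expected here. Compound 4 is expected to give 5%, between -10% and 20%, a step of a number 17 percentage points lower from compound 3 to compound 4 (beyond the scatter) from compound 3, because the earlier instance gave a number 43 percentage points lower from compound 1 to compound 2 (beyond the scatter).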

Compound 4, a percentage reported as inhibition, at one concentration (the size of the read-out at that concentration, not a potency): 18%
Beside the measured number, compound 4's estimate is 13 percentage points below it, within the range that was stated.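

In this assay, benzyl in place of tert-butyl gives a number 4 percentage points lower from compound 3 to compound 4 (within the scatter), and this step does not match the one seen for the same change on the core of compound 1: the same change on two cores in this assay, a number 43 percentage points lower (beyond the scatter) from compound 1 to compound 2 and a number 4 percentage points lower (within the scatter) from compound 3 to compound 4, 39 percentage points apart, beyond the scatter of two such steps. Thiophen-2-yl in place of furan-2-yl gives a number 7 percentage points higher from compound 2 to compound 4 (within the scatter), and this step likewise depends on the group carried on the oxygen: the same change on two cores in this assay, a number 32 percentage points lower (beyond the scatter) from compound 1 to compound 3 and a number 7 percentage points higher (within the scatter) from compound 2 to compound 4, 39 percentage points apart, beyond the scatter of two such steps. In these four compounds, therefore, neither change carries from one core to another as a fixed amount, but the set is a single square of compounds and shows neither why the steps differ nor how either change would behave on any other core.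

The compounds shown leave open what a methyl or ethyl group, or a longer chain, on that oxygen would give, and what a phenyl group on the saturated ring carbon would give. They also leave open whether the order seen at this one concentration would hold in a full potency measurement.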